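This account rests on a few compounds, and the source may have more. Where it says the series, first, only, none or still open, it means among the compounds named here.

Measured so far:
compound 1 `COc1ccc2c(c1)c(O)c(C1=CS(=O)(=O)c3cc(NS(C)(=O)=O)ccc3N1)c(=O)n2Cc1ccc(F)cc1` — > 50000 nM
compound 2 `CS(=O)(=O)Nc1ccc2c(c1)S(=O)(=O)C=C(c1c(O)c3cc(F)ccc3n(Cc3ccccc3)c1=O)N2` — > 50000 nM

In an ADME assay on 2209-23 cells (Homo sapiens) for cytotoxicity, read by WST assay (on this read-out higher numbers stand for lower toxicity in this test and lower numbers for higher toxicity in this test), compound 1 gives > 50000 nM, a limit of the assay and not a number. Compound 2 likewise gives only a limit, > 50000 nM. Both values sit at the same point, (the limit of > 50000 nM in this assay, at which 2 of the 2 values shown sit), so compound 2 stands level with compound 1 there. Compound 3 `CCCC(C)n1c(=O)c(C2=CS(=O)(=O)c3cc(NS(C)(=O)=O)ccc3N2)c(O)c2cc(F)ccc21` differs from compound 2 by 1-methylbutyl in place of benzyl on an aromatic nitrogen. Within the data shown here, with no measured step available, no shift beyond the scatter is expected, the step from compound 2 to compound 3 being estimated as a number no higher from compound 2 to compound 3 (the limit leaves the size open). Compound 3 is expected to give 50000 nM, range 25000 nM to 100000 nM, most probably again as a limit.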

Compound 3, half-maximal cytotoxic concentration: > 50000 nM
Compound 3: only a limit was reported; the forecaster's own chance of this, stated with the estimate: 85%; the middle value sits exactly at the limit.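

No step from compound 2 to compound 3 can be read, since both values are limits: the limit of > 50000 nM in this assay, at which 3 of the 3 values shown sit.

The compounds shown leave open whether 1-methylbutyl in place of benzyl on the aromatic nitrogen changes cytotoxicity at all.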